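A few compounds are considered here, and "the series" means these few. Any claim that something is new, unique, unknown or untested is made for them only; others in the source may bear on it.

Measured so far:
compound 1 `COc1ccc(-c2ccc(-c3ccc(C(=N)N)cc3)s2)cc1` — 773 nM
compound 2 `N=C(N)c1ccc(-c2ccc(-c3cc(Cl)cc(Cl)c3)s2)cc1` — 1750 nM

In a functional assay on PC-3 cells (Homo sapiens) for inhibition, read by sulforhodamine B assay, with a stated time of 48 h (a higher number here means a weaker inhibitor of growth, a lower number a stronger inhibitor of growth), compound 1 gives 773 nM, the lower of the two numbers shown. Compound 2 gives 1750 nM, a gap from compound 1 that lies beyond the usual scatter. Compound 3 `N=C(N)c1ccc(-c2ccc(-c3ccc(F)cc3)s2)cc1` remains to be measured. It differs from compound 1 by fluoro in place of methoxy on an aromatic carbon. Among the measured compounds shown here, no measured pair shows a change of this kind, so the size of the step cannot be read from the data; a small step, within the scatter or a little toward a higher number, is expected. Compound 3 is expected near 1000 nM, within 400 nM to 2500 nM. The step of a 1.3-fold higher number from compound 1 to compound 3 (0.11 log units; within the scatter) is thus the expected outcome.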

Compound 3, concentration for 50% growth inhibition: 1590 nM
For compound 3 the middle estimate is 1.6-fold (0.20 log units) below the measured one, and the stated range covers the measured number.
By their numbers in this assay, from the lowest: compound 1; then compounds 3 and 2 (each within the scatter of the next).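

In this assay, among the compounds shown here, the change of methoxy to fluoro gives a 2.1-fold higher number from compound 1 to compound 3 (0.31 log units; beyond the scatter), the first one-place comparison. The carbon para to a large group on the six-membered aromatic ring therefore responds to its substituent, though modestly, and methoxy there gives the lower number of this pair. Nothing measured here bears on the reason for this step.

With one pair, no trend at this position can be drawn. Where hydroxy, an amine or a longer chain such as ethoxy on the same carbon would fall relative to compound 1 and compound 3 remains open.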